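A few compounds are considered here, and "the series" means these few. Any claim that something is new, unique, unknown or untested is made for them only; others in the source may bear on it.

Two compounds of the series carry a measurement in a functional assay on NCI-H1581 cells (Homo sapiens) for inhibition, read by MTT assay, with a stated time of 48 h, tested at 10 uM; a higher number here means more inhibition at the concentration tested (going by the name of the read-out), a lower number less inhibition. Compound 1 `COc1cc(NC(=O)Nc2cc(Nc3ccc(C)c(F)c3)ncn2)cc(OC)c1` gives 38% in this assay, the lower of the two numbers shown. Compound 2 `COc1cc(Br)ccc1Nc1cc(NC(=O)Nc2c(Cl)cccc2Cl)ncn1` gives 47.3% in this assay, a value within the scatter of that of compound 1, so the two cannot be ordered.

Compound 3 `COc1cc(NC(=O)Nc2cc(Nc3cc(I)ccc3OC)ncn2)cc(OC)c1` has not been measured. Relative to compound 1 the change is 5-iodo-2-methoxyphenyl in place of 3-fluoro-4-methylphenyl on a nitrogen on an aromatic ring. Among the compounds with values here, no measured pair isolates this change, so the size of the step from compound 1 to compound 3 in this assay is expected to stay within the scatter or be a modest rise, as a number 7 percentage points higher from compound 1 to compound 3 (within the scatter). The estimate for compound 3 is 45%, with a range from 25% to 65%.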

Compound 3, a percentage reported as inhibition, at one concentration (the size of the read-out at that concentration, not a potency): 59%
For compound 3 the middle estimate is 14 percentage points below the measured one; the measured number falls inside the stated range.
By their numbers in this assay, from the lowest: compounds 1 and 2 (each within the scatter of the next); then compound 3.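

On a nitrogen on an aromatic ring, the aryl group is a place where the series responds in this assay: 5-iodo-2-methoxyphenyl in place of 3-fluoro-4-methylphenyl gives a number 21 percentage points higher from compound 1 to compound 3 (beyond the scatter). Within the data shown here, this is the first single-place change that can be read, and it leaves the rest of compound 1 untouched. Nothing measured here accounts for the rise.

On these data alone, the change replaces both ring substituents at once, so it remains open whether the iodine or the methoxy carries the step. Also open, as far as these compounds go, is how an amine or a carboxylic acid in place of the iodine would read.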